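A few compounds are considered here, and "the series" means these few. Any claim that something is new, unique, unknown or untested is made for them only; others in the source may bear on it.

Compound 1 `COc1ccc(S(=O)(=O)/C=C/C(=O)Nc2ccc(Oc3ccnc4cc(OCCCN5CCN(C)CC5)c(OC)cc34)c(F)c2)cc1` gives 1660 nM in a functional assay on HT-29 cells (Homo sapiens) for cytotoxicity, read by MTT assay, with a stated time of 72 h; a higher number here means a weaker inhibitor, a lower number a stronger inhibitor. Compound 2 `COc1cc2c(Oc3ccc(NC(=O)/C=C/S(=O)(=O)c4ccc(C)cc4)cc3F)ccnc2cc1OCCCN1CCN(C)CC1` differs from compound 1 by methyl in place of methoxy on an aromatic carbon and in this assay compound 2 gives 2070 nM; that change made a 1.2-fold higher number from compound 1 to compound 2 (0.10 log units; within the scatter). Compound 3 `COc1ccc(S(=O)(=O)/C=C/C(=O)Nc2ccc(Oc3ccnc4cc(OCCCN5CCCCC5)c(OC)cc34)c(F)c2)cc1` carries another core, differing from compound 1 by piperidin-1-yl in place of 4-methylpiperazin-1-yl on a saturated chain carbon, three bonds along the chain from an oxygen on an aromatic ring. In this assay compound 3 gives 1650 nM. That change of core made a 1.0-fold lower number from compound 1 to compound 3 (0.00 log units; within the scatter). Compound 4 `COc1cc2c(Oc3ccc(NC(=O)/C=C/S(=O)(=O)c4ccc(C)cc4)cc3F)ccnc2cc1OCCCN1CCCCC1` is not yet measured; it differs from compound 3 by methyl in place of methoxy on an aromatic carbon, the same change as that seen between compound 1 and compound 2, here made on the core of compound 3. For compound 4 the writer expects a step of a 1.2-fold higher number from compound 3 to compound 4 (0.08 log units; within the scatter) because the same change earlier gave a 1.2-fold higher number from compound 1 to compound 2 (0.10 log units; within the scatter). Compound 4 is therefore estimated at 2000 nM in this assay, expected to lie between 1000 nM and 4000 nM.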

Compound 4, half-maximal inhibitory concentration: 4230 nM
For compound 4 the middle estimate is 2.1-fold (0.33 log units) below the measured one; the measured number lies above the stated range.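

In this assay, methyl in place of methoxy with the piperidin-1-yl group in the chain gives a 2.6-fold higher number from compound 3 to compound 4 (0.41 log units; beyond the scatter), but this step cannot be told apart from the one seen with the 4-methylpiperazin-1-yl group: the same change on two cores in this assay, a 1.2-fold higher number (0.10 log units; within the scatter) from compound 1 to compound 2 and a 2.6-fold higher number (0.41 log units; beyond the scatter) from compound 3 to compound 4, 2.1-fold (0.31 log units) apart, within the scatter of two such steps. Piperidin-1-yl in place of 4-methylpiperazin-1-yl, carried onto the 4-methylphenyl sulfone, gives a 2.0-fold higher number from compound 2 to compound 4 (0.31 log units; beyond the scatter), and this too stands unseparated from its counterpart: the same change on two cores in this assay, a 1.0-fold lower number (0.00 log units; within the scatter) from compound 1 to compound 3 and a 2.0-fold higher number (0.31 log units; beyond the scatter) from compound 2 to compound 4, 2.1-fold (0.31 log units) apart, within the scatter of two such steps. The four compounds therefore give no firm sign that either change behaves differently from one core to the other, but with one pair of steps for each change, they do not show that the changes carry over unaltered either.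

What the compounds shown leave open is how a chloro group or an unsubstituted phenyl ring would behave in place of the methoxy or methyl group. Also open, on these data alone, is whether a morpholin-4-yl group or a longer chain would follow the same trend.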